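Replacing Chloro with Fluoro on the Shared Core

The source may hold more compounds than are shown below. What is called first, only, known or untested is meant among the compounds shown, and "the series" means these compounds.

In a functional assay on OCI-Ly3 cells (Homo sapiens) for antiproliferative activity (on this read-out higher numbers stand for an effect only at larger amounts of compound and lower numbers for an effect already at smaller amounts), compound 1 `Cc1c(NC(=O)Nc2cnc(-n3nccn3)c(Cl)c2)cnc2ccccc12` gives 7170 nM as its value, compound 2 `O=C(Nc1cnc(-n2nccn2)c(Cl)c1)Nc1cnc2ccccc2c1C1CC1` gives 1580 nM and compound 3 `O=C(Nc1cnc(-n2nccn2)c(Cl)c1)Nc1cnc2ccc(Cl)cc2c1C1CC1` gives 990 nM as its value. Compound 3 thus stands clearly under compound 1, while it cannot be told apart from compound 2 beyond the scatter.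

Compound 4 `O=C(Nc1cnc(-n2nccn2)c(Cl)c1)Nc1cnc2ccc(F)cc2c1C1CC1` differs from compound 3 in one group only: fluoro in place of chloro on an aromatic carbon (fluoro in place of chloro on an aromatic carbon of a six-membered aromatic ring of carbon only, part of a fused or bridged system of two rings).

The measured step that bears on this change is chloro in place of hydrogen on an aromatic carbon, which gave a 1.6-fold lower number from compound 2 to compound 3 (0.20 log units; within the scatter) as its size. Cyclopropyl in place of methyl on an aromatic carbon gave a 4.5-fold lower number from compound 1 to compound 2 (0.66 log units; beyond the scatter) as its size, but it concerns a different group and bears little on this change. Since adding the chloro group to compound 2 moved the number only within the scatter, no step beyond the scatter is expected in this assay when fluoro replaces it. The expected change is small, with a slightly higher number estimated as a 1.3-fold higher number from compound 3 to compound 4 (0.10 log units; within the scatter) (an expectation only). Compound 4 is estimated at 1250 nM (expected range 620 nM to 2500 nM).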

Compound 4, half-maximal effective concentration: 720 nM
For compound 4 the middle estimate is 1.7-fold (0.24 log units) above the measured one, and the stated range covers the measured number.
By their numbers in this assay, from the lowest: compounds 4, 3 and 2 (each within the scatter of the next, the first and the last beyond it); then compound 1.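

In this assay the exchange of chloro for fluoro gives a 1.4-fold lower number from compound 3 to compound 4 (0.14 log units; within the scatter) and so does not separate the two halogens at this position. Among these compounds, measured against the hydrogen of the parent compound, however, fluoro gives a 2.2-fold lower number from compound 2 to compound 4 (0.34 log units; beyond the scatter) and is the first group at this position whose step passes beyond the scatter, which chloro did not do; the margin is narrow, and compound 3 remains within the scatter of both compound 2 and compound 4, so the series shows a small gain with fluoro rather than a clear difference between fluoro and chloro. Nothing available here accounts for this small difference between the two halogens or for the step from hydrogen.

The compounds shown leave open whether a larger or differently built group at this same position, such as methoxy, an amine or a nitrile, would carry the number further in either direction. They also leave open whether fluoro would give a similar step on the shared core with methyl in place of cyclopropyl, the background of compound 1.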